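The compounds below may be only part of what the source reports. "The series", "measured", "known", "first", "only" and "open" are said of these compounds alone.

Three measured chalcones frame the question. Compound 1 `CCOc1ccc(C(=O)/C=C/c2ccc(C)cc2)cc1` gives 210 nM in an assay on isolated protein for inhibition of Amine oxidase [flavin-containing] B (Homo sapiens); a lower number here means a stronger inhibitor, a higher number a weaker inhibitor. Compound 2 `CCc1ccc(/C=C/C(=O)c2ccc(-n3ccnc3)cc2)cc1` gives 320 nM, and compound 3 `O=C(/C=C/c1ccc(Br)cc1)c1ccc(-n2ccnc2)cc1` gives 320 nM. Compound 3 thus stands level with compound 2 at the digits shown, the two together forming the highest pair of the three numbers, while compound 1 lies a little lower, though within the scatter of compound 3. Among the measured compounds shown here, the only one-place step among them, from compound 2 to compound 3, reads no change at the digits printed from compound 2 to compound 3 (within the scatter), a bromo in place of ethyl on an aromatic carbon that leaves the number untouched.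

Compound 4 `Cc1ccc(/C=C/C(=O)c2ccc(-n3ccnc3)cc2)cc1` now takes the same step one group further: methyl in place of bromo on an aromatic carbon, on the six-membered aromatic ring of carbon only, para to a large group. The step from compound 2 to compound 3 is the one that bears on this, and it was flat. Compound 1, which carries the same methyl on a different core, shows a number close to compound 3. The expectation for compound 4 is therefore a step of a 1.1-fold lower number from compound 3 to compound 4 (0.06 log units; within the scatter), that is none beyond the scatter, with compound 4 estimated at 280 nM, between 130 nM and 600 nM.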

Compound 4, half-maximal inhibitory concentration: 320 nM
Compound 4: the middle estimate sits 1.1-fold (0.06 log units) below what was measured; the measured number falls inside the stated range.
By their numbers in this assay, from the lowest: compounds 1, 2, 3 and 4 (each within the scatter of the next).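

In this assay the change from 4-bromophenyl to 4-methylphenyl gives no change at the digits printed from compound 3 to compound 4 (within the scatter) and, with the step from ethyl to methyl giving no change at the digits printed from compound 2 to compound 4 (within the scatter) on the same shared core, the three groups tried at this place, para to a large group, cannot be told apart. Compound 4 also supplies the first one-place link to compound 1: with the methyl held fixed, the change of ethoxy to 1H-imidazol-1-yl gives a 1.5-fold higher number from compound 1 to compound 4 (0.18 log units; within the scatter) and so cannot be told from scatter either. Nothing shown here bears on why these numbers coincide.

Going by these compounds, whether this place stays as flat with an amine, a carboxylic acid or a longer chain such as butyl remains open. So does whether a group other than ethoxy or 1H-imidazol-1-yl at the second place would shift the number.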